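This account rests on a few compounds, and the source may have more. Where it says the series, first, only, none or still open, it means among the compounds named here.

The measured compounds:
compound 1, `CCC(=O)N1N=C(C)CC1c1cc(Br)cc(Br)c1O`: 38600 nM
compound 2, `O=C(c1ccccc1)N1N=C(c2cc3ccccc3oc2=O)CC1c1ccccc1`: 12700 nM

In a functional assay on MGC-803 cells (Homo sapiens) for cytotoxicity, read by MTT assay, with a stated time of 48 h (on this read-out higher numbers stand for weaker inhibition and lower numbers for stronger inhibition), compound 2 gives 12700 nM, the lower of the two numbers recorded, while compound 1 gives 38600 nM, a higher number; this gap lies beyond the usual scatter of repeated measurements. Among the measured compounds shown here, no two measured compounds differ in only one place, so no single structural change has yet been followed in this assay. Compound 3, `O=C(c1ccccc1Cl)N1N=C(c2cc3ccccc3oc2=O)CC1c1ccccc1`, comes from compound 2 by one change: chloro in place of hydrogen on an aromatic carbon. Nothing measured here shows what such a change does, so the expectation rests on compound 2 alone, whose 12700 nM serves as the starting point. The step that the estimate implies, a 1.3-fold lower number from compound 2 to compound 3 (0.10 log units; within the scatter), is expected to be no larger than the scatter, in either direction. Compound 3 is therefore estimated at 10000 nM, within a range from 3500 nM to 30000 nM.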

Compound 3, half-maximal inhibitory concentration: 6640 nM
For compound 3 the middle estimate is 1.5-fold (0.18 log units) above the measured one; low and high end bracket the measured number.
By their numbers in this assay, from the lowest: compounds 3 and 2 (each within the scatter of the next); then compound 1.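

In this assay, among the compounds shown here, the change from benzoyl to (2-chlorophenyl)carbonyl gives a 1.9-fold lower number from compound 2 to compound 3 (0.28 log units; within the scatter) and is the first single change that can be followed. For the compounds shown here, on this read-out compound 2 and compound 3 cannot be told apart, so one added heavy atom, a chloro group at this place on the ring, produces no step past the usual scatter. Nothing measured here helps to explain the size of this step.

Going by these compounds, it remains open whether a different group at this same place, such as methoxy or an amine, or a chloro group on another carbon of this ring, would give a step beyond the scatter. Compound 1 differs from both compounds in more than one place, so it cannot help to settle this.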